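Swapping the aminophenyl for a difluorophenyl group

The source may report more compounds than this note shows. Statements on the series, on what has been measured and on what is new or still open speak of the compounds shown alone.

Measured compounds:
compound 1: `COc1ccc(-c2cc(/C=C/C(=O)c3ccc(N)cc3)[nH]n2)cc1` — in a functional assay on SF-539 cells (Homo sapiens) for inhibition, read by sulforhodamine B assay, with a stated time of 48 h (a higher number here means a weaker inhibitor of growth, a lower number a stronger inhibitor of growth), compound 1 gives 1470 nM
compound 2: `COc1cc(-c2cc(/C=C/C(=O)c3ccc(N)cc3)[nH]n2)cc(OC)c1OC` — compound 2 gives 1300 nM
compound 3: `COc1cc(-c2cc(/C=C/C(=O)c3ccc(Cl)c(Cl)c3)[nH]n2)cc(OC)c1OC` — compound 3 gives 4310 nM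

Compound 2 has the lowest number of the three, but compound 1 sits so close to it that the two cannot be told apart. Compound 3 stands clearly further away: a 3.3-fold higher number from compound 2 to compound 3 (0.52 log units; beyond the scatter), a modest step toward weaker growth inhibition.

Compound 4 is the unmeasured analogue `COc1cc(-c2cc(/C=C/C(=O)c3ccc(F)c(F)c3)[nH]n2)cc(OC)c1OC`. It differs from compound 2 as follows: 3,4-difluorophenyl in place of 4-aminophenyl on a carbonyl carbon. Going by the values given here, only one measured step bears on this change, namely the one from compound 2 to compound 3, where the same 4-aminophenyl gave way to 3,4-dichlorophenyl on the same carbonyl carbon. That step was modest and beyond the scatter. Because the step from compound 2 to compound 3 was a 3.3-fold higher number from compound 2 to compound 3 (0.52 log units; beyond the scatter), a step in the same direction is expected here, of broadly similar size: a 2.3-fold higher number from compound 2 to compound 4 (0.36 log units; beyond the scatter). Compound 4 is therefore estimated at 3000 nM, within a range from 1500 nM to 6500 nM.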

Compound 4, concentration for 50% growth inhibition: 3760 nM
Compound 4: the middle estimate sits 1.3-fold (0.10 log units) below what was measured, within the range that was stated.
By their numbers in this assay, from the lowest: compounds 2 and 1 (each within the scatter of the next); then compounds 4 and 3 (each within the scatter of the next).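

In this assay, the 3,4-difluorophenyl group on the carbonyl carbon also gives weaker growth inhibition than the 4-aminophenyl, with a 2.9-fold higher number from compound 2 to compound 4 (0.46 log units; beyond the scatter). The loss seen earlier is therefore not tied to the dichloro compound alone: both halogen-bearing phenyl groups tested at this place read weaker than the 4-aminophenyl. Fluorine and chlorine cannot be told apart here, with a 1.1-fold lower number from compound 3 to compound 4 (0.06 log units; within the scatter).

No measurement at hand gives a reason for these steps. As far as these compounds go, it remains open whether the 4-aminophenyl is favoured for its amine or whether the two halogens are what weakens growth inhibition, a question that a plain phenyl group or a 4-hydroxyphenyl group at the same carbonyl carbon could help to separate.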